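Shortening the linker and swapping the halogen on the sulfonamide

The source may report more compounds than this note shows. Statements on the series, on what has been measured and on what is new or still open speak of the compounds shown alone.

Measured so far:
- compound 1 `O=S(=O)(NCCCNc1nccc(-c2c(-c3cccc(F)c3)nc3sccn23)n1)c1cccc(F)c1`, 13700 nM in a functional assay on A-375 cells (Homo sapiens) for cytotoxicity, read by MTT assay; on this read-out higher numbers stand for weaker inhibition and lower numbers for stronger inhibition
- compound 2 `O=S(=O)(NCCCNc1nccc(-c2c(-c3cccc(F)c3)nc3sccn23)n1)c1ccc(Br)cc1`, 7040 nM
- compound 3 `COc1ccc(S(=O)(=O)NCCCNc2nccc(-c3c(-c4cccc(F)c4)nc4sccn34)n2)cc1`, 5510 nM

Among these three, compound 2 sits second highest; its nearest neighbour is compound 3 a 1.3-fold lower number from compound 2 to compound 3 (0.11 log units; within the scatter), and compound 1 lies furthest a 1.9-fold lower number from compound 1 to compound 2 (0.29 log units; within the scatter). Compound 4 `O=S(=O)(NCCNc1nccc(-c2c(-c3cccc(F)c3)nc3sccn23)n1)c1ccc(F)cc1` differs from compound 2 by ((4-fluorophenyl)sulfonyl)amino in place of (((4-bromophenyl)sulfonyl)amino)methyl on a saturated chain carbon, two bonds along the chain from a nitrogen on an aromatic ring. The measured steps change only the aryl group on the sulfonyl sulfur; none touch the chain length, and the largest of them, a 2.5-fold lower number from compound 1 to compound 3 (0.40 log units; beyond the scatter), is modest. Compound 4 is therefore expected to stay close to compound 2, with a 1.4-fold higher number from compound 2 to compound 4 (0.15 log units; within the scatter), so the estimate for compound 4 is 10000 nM, within 3000 nM to 30000 nM.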

Compound 4, half-maximal inhibitory concentration: 9450 nM
Beside the measured number, compound 4's estimate is 1.1-fold (0.02 log units) above it; measured number inside the range.
By their numbers in this assay, from the lowest: compounds 3, 2, 4 and 1 (each within the scatter of the next, the first and the last beyond it).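

On this assay the replacement of (((4-bromophenyl)sulfonyl)amino)methyl by ((4-fluorophenyl)sulfonyl)amino gives a 1.3-fold higher number from compound 2 to compound 4 (0.13 log units; within the scatter) and the matching replacement of (((3-fluorophenyl)sulfonyl)amino)methyl gives a 1.4-fold lower number from compound 1 to compound 4 (0.16 log units; within the scatter) and so the first change shown at this chain carbon stays within the scatter of both compounds. Each step alters the aryl group along with the chain, so the two changes cannot be separated here. No evidence is available that explains this result. On these data alone, the effect of a longer chain remains open, as does that of an amine or a carboxylic acid in place of the halogen.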